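The compounds below may be only part of what the source reports. "The series", "measured", "known", "first", "only" and "open" are said of these compounds alone.

Compound 1 `CCCN(CCC)c1ccc(NC(=O)c2cc(Cl)ccc2O)c(Cl)c1` was tested in an ADME assay on A549 cells (Homo sapiens) for cytotoxicity, read by LDH release, with a stated time of 15 h; a lower number here means that less compound is tolerated, a higher number that more compound is tolerated. In this assay compound 1 gives 323000 nM, the highest of the two numbers available. Compound 3 `CCCC(C)(C)Nc1ccc(NC(=O)c2cc(Cl)ccc2O)c(Cl)c1` gives 23700 nM, and the step of a 14-fold lower number from compound 1 to compound 3 (1.13 log units; beyond the scatter) accompanied the exchange of dipropylamino for (1,1-dimethylbutyl)amino. For compound 2 `O=C(Nc1ccc(N2CCCC2)cc1Cl)c1cc(Cl)ccc1O` the entry in this assay is "not determined" (no result reported), so no result was reported. Compound 4 `CCCNc1ccc(NC(=O)c2cc(Cl)ccc2O)c(Cl)c1` differs from compound 1 by hydrogen in place of propyl on a nitrogen on an aromatic ring. Among the measured compounds shown here, the single step measured, from compound 1 to compound 3, was large and also altered the group on that nitrogen, but a different group entered there, so it bears only loosely on the present change. The expected step is a 2.2-fold lower number from compound 1 to compound 4 (0.33 log units; beyond the scatter), toward a lower number. Compound 4 is therefore estimated at 150000 nM, with a range from 50000 nM to 450000 nM.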

Compound 4, half-maximal cytotoxic concentration: 69700 nM
The estimate for compound 4 lay 2.2-fold (0.33 log units) above the measured number, within the range that was stated.
By their numbers in this assay, from the lowest: compound 3; then compound 4; then compound 1.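

In this assay the change from dipropylamino to propylamino gives a 4.6-fold lower number from compound 1 to compound 4 (0.67 log units; beyond the scatter) and shows that the number responds even when hydrogen simply replaces propyl on this nitrogen. With one chain kept there, propyl in place of 1,1-dimethylbutyl gives a 2.9-fold higher number from compound 3 to compound 4 (0.47 log units; beyond the scatter) and places compound 4 between the other two compounds, so the identity of that chain also matters. No measurement available here explains either step. The compounds shown leave open how a methyl or an ethyl on this nitrogen would compare with propyl. They also leave open where a plain primary amine, with hydrogen in place of both chains, would fall.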